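Removing one methoxy from a triazole-linked aryl ketone

This account rests on a few compounds, and the source may have more. Where it says the series, first, only, none or still open, it means among the compounds named here.

Compound 1, `C=CCn1c(SCC(=O)c2ccccc2)nnc1-c1ccccc1`, in a functional assay on the whole organism (strain albino) for inhibition, with Rattus norvegicus as the target, read by paw edema, with a stated time of 1 h, at a dose of 0.28 mmol/kg by the oral route (a lower number here means less inhibition, a higher number more inhibition at the dose given (going by the name of the read-out)), gives 43%.
Compound 2, `C=CCn1c(SCC(=O)c2ccccc2)nnc1-c1ccc(OC)c(OC)c1`, in this assay gives 61%.

For the measured compounds named here, of the two compounds measured so far, compound 2 stands highest in this assay, and its nearest neighbour is compound 1, whose value lies lower by a gap that exceeds the usual scatter of repeated measurements. Compound 3, `C=CCn1c(SCC(=O)c2ccccc2)nnc1-c1ccc(OC)cc1`, has not yet been measured. Relative to compound 2, the change is hydrogen in place of methoxy on an aromatic carbon; the methoxy group that is lost sat ortho to a methoxy group and meta to a large group, so compound 3 keeps a single methoxy on that ring.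

Going by the values given here, no step between measured compounds has been worked out, so the expectation for compound 3 rests on the spread between compound 1 and compound 2 alone. Since compound 3 sits structurally between them, the step from compound 2 to compound 3 in this assay is expected to be small and downward, at about a number 9 percentage points lower from compound 2 to compound 3 (within the scatter), a size that may well stay inside the scatter. Compound 3 is therefore estimated at 52%, with a range from 38% to 66%.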

Compound 3, a percentage reported as inhibition, in the whole organism at one dose (the size of the read-out at that dose, not a potency): 49%
Estimate against measurement, compound 3: 3 percentage points above, within the range that was stated.
By their numbers in this assay, from the lowest: compounds 1 and 3 (each within the scatter of the next); then compound 2.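

Removing the methoxy group that sat ortho to a methoxy group and meta to a large group has an effect that can be read in this assay, with a step of a number 12 percentage points lower from compound 2 to compound 3 (beyond the scatter), so this position matters when a second methoxy remains on the ring. For the compounds shown here, the earlier pair could not show this, since compound 1 and compound 2 differ in more than one place, and the new comparison with compound 1, which has no methoxy on that ring, gives a different picture: the single methoxy brings a step of a number 6 percentage points higher from compound 1 to compound 3 (within the scatter), which cannot be told apart from no change. Of the two steps, then, only the loss of a methoxy from the ring that carries two stands clear of the scatter, and nothing available here explains why the two steps differ.

The compounds shown leave open whether an ethoxy group, a hydroxyl or an amine at the position of the lost methoxy would keep the inhibition seen with compound 2. They also leave open how a fluorine or a carboxylic acid on the ring of the aryl ketone, which stays the same in all three compounds, would change the read-out.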